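The compounds below may be only part of what the source reports. "The series", "measured", "known", "first", "only" and "open" are said of these compounds alone.

Working notes on the series in a functional assay on HT-29 cells (Homo sapiens) for inhibition, read by sulforhodamine B assay, with a stated time of 48 h; a lower number here means a stronger inhibitor of growth, a higher number a weaker inhibitor of growth.

Among the compounds with values here, compound 3 `CC1=CC[C@H](C(C)(C)NC(=S)N/N=C/c2ccco2)CC1` gives 26900 nM in this assay, the second highest of the three numbers so far. Compound 1 `COc1ccc(/C=N/NC(=S)NC(C)(C)[C@H]2CC=C(C)CC2)cc1` gives 33600 nM and sits nearest, while compound 2 `CC1=CC[C@H](C(C)(C)NC(=S)N/N=C/c2ccccc2O)CC1` gives 16600 nM and sits furthest. Among the measured steps, only a 2.0-fold lower number from compound 1 to compound 2 (0.31 log units; beyond the scatter) lies beyond the scatter, whereas a 1.2-fold lower number from compound 1 to compound 3 (0.10 log units; within the scatter) and a 1.6-fold higher number from compound 2 to compound 3 (0.21 log units; within the scatter) both stay within it, so the group on the carbon with a double bond to nitrogen has so far moved the read-out little.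

Compound 4 `CC1=CC[C@H](C(C)(C)NC(=S)N/N=C/c2cccs2)CC1` is the next member. The change from compound 3 is thiophen-2-yl in place of furan-2-yl on a carbon with a double bond to nitrogen. Within the data shown here, no measured pair swaps one five-membered aromatic ring with one hetero atom for another, so nothing bears directly on this step; the closest analogues are the exchanges at the same carbon, where a 1.2-fold lower number from compound 1 to compound 3 (0.10 log units; within the scatter) and a 1.6-fold higher number from compound 2 to compound 3 (0.21 log units; within the scatter) were within the scatter and a 2.0-fold lower number from compound 1 to compound 2 (0.31 log units; beyond the scatter) was only modest. On that basis compound 4 is expected to show a step from compound 3 that is within the scatter, that is a 1.2-fold lower number from compound 3 to compound 4 (0.09 log units; within the scatter), with no direction favoured. The estimate for compound 4 is therefore 22000 nM, with a range from 9000 nM to 50000 nM.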

Compound 4, concentration for total growth inhibition: 57800 nM
For compound 4 the middle estimate is 2.6-fold (0.42 log units) below the measured one, outside the stated range (above it).
By their numbers in this assay, from the lowest: compounds 2, 3, 1 and 4 (each within the scatter of the next, the first and the last beyond it).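

In this assay, within the data shown here, the exchange of thiophen-2-yl for furan-2-yl on a carbon with a double bond to nitrogen gives a 2.1-fold higher number from compound 3 to compound 4 (0.33 log units; beyond the scatter) and is the first step to keep one five-membered aromatic ring with 1 hetero atom, changing only that atom from oxygen to sulfur. This position therefore responds beyond the scatter to a change that leaves the heavy-atom, donor and acceptor counts as they were, although the step is modest. The same group gives a 3.5-fold higher number from compound 2 to compound 4 (0.54 log units; beyond the scatter), the largest step at this carbon so far and beyond the scatter, but also a 1.7-fold higher number from compound 1 to compound 4 (0.24 log units; within the scatter), which stays within it, so thiophen-2-yl cannot be told apart from 4-methoxyphenyl here, and no measurement at hand accounts for the difference between the two five-membered rings.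

The compounds shown leave open whether a pyrrol-2-yl group at this carbon would read with furan-2-yl or with thiophen-2-yl. They also leave open whether an unsubstituted phenyl would read with 2-hydroxyphenyl or with 4-methoxyphenyl, and so whether the hydroxyl of compound 2 matters on its own.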